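The source may hold more compounds than are shown below. What is called first, only, known or untested is meant among the compounds shown, and "the series" means these compounds.

Measured in an in vitro ADME assay on microsomes from liver (Rattus norvegicus) for metabolic stability; on this read-out higher numbers stand for fast clearance and lower numbers for slow clearance:
- compound 1 `Nc1cc(Nc2ccc(Oc3ccc(Cl)cc3)cc2)ncn1`: 32 mL.min-1.g-1
- compound 2 `Nc1nccc(Nc2ccc(Oc3ccc(Cl)cc3)cc2)n1`: 41 mL.min-1.g-1
- compound 3 `Nc1cc(Nc2ccc(Oc3ccc(Cl)cc3)cc2)cnn1`: > 399 mL.min-1.g-1

Compound 3 reads > 399 mL.min-1.g-1, which is a limit and not a number. That reading is the limit of > 399 mL.min-1.g-1 in this assay, at which 1 of the 3 values shown sits.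

Compound 4 `Nc1nnc(Nc2ccc(Oc3ccc(Cl)cc3)cc2)s1` has 5-amino-1,3,4-thiadiazol-2-yl in place of 6-aminopyridazin-4-yl on a nitrogen on an aromatic ring. Two measured steps bring in the leaving group: an at least 12-fold higher number from compound 1 to compound 3 (1.09 log units; beyond the scatter) is large and an at least 9.7-fold higher number from compound 2 to compound 3 (0.98 log units; beyond the scatter) is at least modest, both beyond the scatter. In contrast, a 1.3-fold higher number from compound 1 to compound 2 (0.11 log units; within the scatter) lies within it. Going by the values given here, no measured step brings in the entering group. Judging from the size of an at least 9.7-fold higher number from compound 2 to compound 3 (0.98 log units; beyond the scatter), removing the leaving group is expected to give a large step to a lower number in this assay. The expected step is an at least 3.9-fold lower number from compound 3 to compound 4 (0.60 log units; beyond the scatter). For compound 4 the estimated value is 100 mL.min-1.g-1, with an expected range of 25 mL.min-1.g-1 to 390 mL.min-1.g-1.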

Compound 4, intrinsic clearance in microsomes: < 14 mL.min-1.g-1
Compound 4 ended at the assay's limit; the forecaster's own chance of this, stated with the estimate: 15%; middle value at least 7.1-fold (0.85 log units) away from the limit.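

The reading of compound 4 is a limit and not a number: the limit of < 14 mL.min-1.g-1 in this assay, at which 1 of the 4 values shown sits. In this assay, 5-amino-1,3,4-thiadiazol-2-yl at this place gives an at least 28-fold lower number from compound 3 to compound 4 (1.45 log units; beyond the scatter), along with an at least 2.9-fold lower number from compound 2 to compound 4 (0.46 log units; beyond the scatter) and an at least 2.2-fold lower number from compound 1 to compound 4 (0.35 log units; beyond the scatter), so this change goes beyond the scatter against all three six-membered rings, including both aminopyrimidinyl groups. Changing only the group on the nitrogen now reaches both limits of the assay.

As far as these compounds go, the exact size of these three steps stays open. So does the role of the amino group, which a methyl group in its place on the five-membered ring would address.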